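The source may report more compounds than this note shows. Statements on the series, on what has been measured and on what is new or still open speak of the compounds shown alone.

Compound 1, whose structure is `O=C([C@@H]1C[C@H](NCc2ccccc2)CN1)N1CCSC1`, was examined in an assay on a cell-free system (plasma) for inhibition of Dipeptidyl peptidase 4 (Rattus norvegicus), read by fluorescence (on this read-out higher numbers stand for weaker inhibition and lower numbers for stronger inhibition), and gave 171 nM. Compound 2, built as `O=C([C@@H]1C[C@H](NS(=O)(=O)c2ccccc2)CN1)N1CCSC1`, replaces the benzylamine of compound 1 with a benzenesulfonamide on the same core. In this assay compound 2 reaches only a limit of the assay, reported as > 300 nM. Compound 2 thus stands at the weak end of the two values shown, at the point described by the limit of > 300 nM in this assay, at which 1 of the 2 values shown sits.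

Compound 3, with structure `N#Cc1ccc(S(=O)(=O)N[C@@H]2CN[C@H](C(=O)N3CCSC3)C2)cc1`, differs from compound 2 by a single change: cyano in place of hydrogen on an aromatic carbon. Among the compounds with values here, no measured pair in this set differs by a cyano group, so there is no step on which to anchor the size of this change. A difference of this kind is expected to leave the value roughly where compound 2 sits, with the change from a step that the limit leaves unreadable from compound 2 to compound 3 not expected to exceed the scatter. For compound 3 in this assay a value near 500 nM is estimated, within a range from 150 nM to 3000 nM.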

Compound 3, half-maximal inhibitory concentration: > 300 nM
Compound 3 gave a limit, no number (the forecaster's own chance of this, stated with the estimate: 60%); the middle value is on the limit's open side.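

Compound 2 and compound 3 both end at a limit of the assay rather than a number, so no step can be read between them: the limit of > 300 nM in this assay, at which 2 of the 3 values shown sit.

The compounds shown leave open whether cyano in place of hydrogen on the aromatic carbon shifts inhibition at all, and in which direction.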